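Shortening the linker toward a smaller piperidine

This account rests on a few compounds, and the source may have more. Where it says the series, first, only, none or still open, it means among the compounds named here.

In an ADME assay on microsomes from liver (Rattus norvegicus) for metabolic stability, read by LC-MS, using NADPH, at 37 degrees C (on this read-out higher numbers stand for a longer-lived compound and lower numbers for a shorter-lived compound), compound 1 `CC[C@@H]1C[C@H](CC)CN(CCCNC(=O)C2CCN(Cc3nc(-c4ccccc4C)oc3C)CC2)C1` gives 0.0917 h. Compound 3 `CC[C@@H]1C[C@H](CC)CN(CCCNC(=O)C2CCN(Cc3nc(-c4c(F)cccc4F)oc3C)CC2)C1` differs only in its aromatic substituent and gives 0.065 h; the step of a 1.4-fold lower number from compound 1 to compound 3 (0.15 log units; within the scatter) shows that the two numbers are not distinguishable. Compound 2 `Cc1oc(-c2ccc(Cl)c(Cl)c2)nc1CN1CCC(C(=O)NCCCN2C[C@H](C)C[C@H](C)C2)CC1` is reported only as a limit, > 0.5 h, so it contributes no number; the limit of > 0.5 h in this assay, at which 1 of the 3 values shown sits, marks where it sits. Among the two actual numbers, compound 1 holds the upper one, with compound 3 within the scatter of it.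

Compound 4 `Cc1ccccc1-c1nc(CN2CCC(C(=O)NCCN3C[C@H](C)C[C@H](C)C3)CC2)c(C)o1` is the next variation: 3,5-dimethylpiperidin-1-yl in place of (3,5-diethylpiperidin-1-yl)methyl on a saturated chain carbon, two bonds along the chain from an amide-type nitrogen. Among the measured compounds shown here, no measured step touches this part of the molecule, since the only step in hand, from compound 1 to compound 3, changes the aromatic ring instead. There is therefore no measured basis for expecting a step beyond the scatter in this assay. For compound 4 the estimate is 0.1 h, with a range from 0.045 h to 0.22 h. This estimate amounts to an expected 1.1-fold higher number from compound 1 to compound 4 (0.04 log units; within the scatter).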

Compound 4, half-life: > 0.5 h
Compound 4: only a limit was reported; the forecaster's own chance of this, stated with the estimate: 5%; middle value at least 5.0-fold (0.69 log units) from the limit.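

In this assay, among the compounds shown here, the only earlier step, on the aromatic ring, stayed within the scatter, whereas this position at the other end of the molecule clearly moves the read-out. Replacing 2-(3,5-diethylpiperidin-1-yl)ethyl with (3,5-dimethylpiperidin-1-yl)methyl gives an at least 5.4-fold higher number from compound 1 to compound 4 (0.73 log units; beyond the scatter), a step beyond the scatter even though the aromatic ring stays the same. Compound 4 has only a limit and no exact number: the limit of > 0.5 h in this assay, at which 2 of the 4 values shown sit.

This single step combines a shorter chain with smaller groups on the piperidine ring, so the compounds shown cannot tell which of the two accounts for it, and the full size of the step remains unknown. They also leave open how a morpholine or an unsubstituted piperidine would read at this position.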